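The compounds below may be only part of what the source reports. "The series", "measured", "known", "first", "only" and "open" are said of these compounds alone.

Measured compounds:
Compound 1 `O=C(Nc1ccc(Cl)cc1)c1cc(Oc2ccc(/C=C/c3ccccn3)cc2)ccn1`, in a functional assay on HepG2 cells (Homo sapiens) for antiproliferative activity, read by CCK-8 assay, with a stated time of 48 h (on this read-out lower numbers stand for stronger inhibition and higher numbers for weaker inhibition), compound 1 gives 31300 nM.
Compound 2 `CNC(=O)c1cc(Oc2ccc(/C=C/c3ccncc3)cc2)ccn1`, in this assay compound 2 gives 18200 nM.

Compound 2 has the lower of the two numbers, but its nearest neighbour, compound 1, sits within the usual scatter of it, so the two cannot be ranked. For the measured compounds named here, compound 1 and compound 2 differ in two places at once, so no single step between them can be read.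

Compound 3 `O=C(Nc1ccc(Cl)cc1)c1cc(Oc2ccc(/C=C/c3ccncc3)cc2)ccn1` has not yet been measured in this assay. Compared with compound 2 the change is 4-chlorophenyl in place of methyl on an amide-type nitrogen. Going by the values given here, no measured pair isolates this change. Compound 1, which carries the same 4-chlorophenyl group on its amide-type nitrogen, gives 31300 nM, which lies within the scatter of compound 2. The step is therefore expected to be small, a 1.4-fold higher number from compound 2 to compound 3 (0.14 log units; within the scatter), with no direction beyond the scatter. For compound 3 the expected value is 25000 nM, in a range from 8000 nM to 80000 nM.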

Compound 3, half-maximal inhibitory concentration: 56200 nM
Compound 3: the middle estimate sits 2.2-fold (0.35 log units) below what was measured, and the stated range covers the measured number.
By their numbers in this assay, from the lowest: compounds 2, 1 and 3 (each within the scatter of the next, the first and the last beyond it).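

In this assay, for the compounds shown here, 4-chlorophenyl in place of methyl on the amide-type nitrogen gives a 3.1-fold higher number from compound 2 to compound 3 (0.49 log units; beyond the scatter), the first single change at this position that can be read, and it goes towards weaker inhibition. The other single change, pyridin-4-yl in place of pyridin-2-yl with the 4-chlorophenyl amide held constant, gives a 1.8-fold higher number from compound 1 to compound 3 (0.25 log units; within the scatter), so the two pyridine attachments cannot be told apart here. Nothing measured explains either result.

The compounds shown leave open whether the weaker inhibition of compound 3 goes with the aromatic ring itself or with its chlorine, which an unsubstituted phenyl on the same nitrogen would help separate. Equally open, going by these compounds, is how a longer chain, such as ethyl or propyl, or a chain ending in an amine would behave at this position.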